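The compounds below may be only part of what the source reports. "The series", "measured", "known", "first", "only" and "open" are said of these compounds alone.

Measured so far in an ADME assay on SH-SY5Y cells (Homo sapiens) for cytotoxicity, read by MTT assay, with a stated time of 48 h; a lower number here means a stronger inhibitor, a higher number a weaker inhibitor:
compound 1 `COc1ccc(C(=O)/C=C/c2ccc(C(=O)NCc3ccccc3)cc2)c(O)c1` gives > 100000 nM
compound 2 `CCCNC(=O)c1ccc(/C=C/C(=O)c2ccc(OC)cc2O)cc1` gives > 100000 nM
compound 3 `COC(=O)c1ccc(/C=C/C(=O)c2ccc(OC)cc2O)cc1` gives > 100000 nM

Compound 3 has no number in this assay, only the limit > 100000 nM. Going by the values given here, the other two readings are limits too, and the series so far shows (the limit of > 100000 nM in this assay, at which 3 of the 3 values shown sit).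

The next compound is compound 4 `COc1ccc(C(=O)/C=C/c2ccc(C(=O)N(C)c3ccccc3)cc2)c(O)c1`, where methyl(phenyl)amino stands in place of methoxy on a carbonyl carbon whose other neighbours are: aromatic carbon (methyl(phenyl)amino in place of methoxy on a carbonyl carbon).

Among the compounds with values here, two measured steps concern this same carbonyl carbon, a step that the two limits leave unreadable from compound 1 to compound 3 and a step that the two limits leave unreadable from compound 2 to compound 3. A third, a step that the two limits leave unreadable from compound 1 to compound 2, concerns the chain on the amide-type nitrogen. None of the three has a readable size, so none gives a magnitude or a direction to carry over. With the readings for compound 1, compound 2 and compound 3 all limits, no clear change is expected in this assay, and the expected step is a number no higher from compound 3 to compound 4 (the limit leaves the size open). Another limit is the likeliest result. For compound 4 the estimated value is 100000 nM, with an expected range from 50000 nM to 200000 nM.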

Compound 4, half-maximal inhibitory concentration: > 100000 nM
Compound 4: no number, only a limit (the forecaster's own chance of this, stated with the estimate: 80%); the middle value lies on the limit itself.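

No step to compound 4 from compound 1, compound 2 or compound 3 can be read in this assay, since all these readings are limits: the limit of > 100000 nM in this assay, at which 4 of the 4 values shown sit.

The compounds shown leave open whether any substituent on this carbonyl carbon changes the true cytotoxicity.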